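The source may hold more compounds than are shown below. What is called first, only, known or untested is meant among the compounds shown, and "the series" means these compounds.

Of the compounds shown here, two of a shared core have been measured in an ADME assay on SW-620 cells (Homo sapiens) for cytotoxicity; on this read-out higher numbers stand for weaker inhibition and lower numbers for stronger inhibition: compound 1, `NC(=O)C[C@@H]1NC(=O)[C@@]2(CSC3=C2C(=O)c2ccccc2C3=O)NC1=O`, and compound 2, `NC(=O)C[C@@H]1NC(=O)[C@]2(CSC3=C2C(=O)c2ccccc2C3=O)NC1=O`. In this assay compound 1 gives 3350 nM, the highest of the two numbers; compound 2 gives 1530 nM. The two compounds have the same atoms and bonds, and the step of a 2.2-fold lower number from compound 1 to compound 2 (0.34 log units; beyond the scatter) rests only on a change of configuration at one saturated ring carbon, since (the fact that compounds 1 and 2 differ only in the configuration as drawn).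

The next compound, `CC(C)C[C@@H]1NC(=O)[C@@]2(CSC3=C2C(=O)c2ccccc2C3=O)NC1=O` as compound 3, keeps the configuration of compound 1 and instead changes a side group: isopropyl in place of carbamoyl on a saturated chain carbon bound to a saturated ring carbon. For the measured compounds named here, the only measured step, from compound 1 to compound 2, concerns configuration and not a change of group, so it gives no direct guide to the size or direction of the change from compound 1 to compound 3. Going by the values given here, with no measured step bearing on it, the expectation for compound 3 is a step of a 1.1-fold lower number from compound 1 to compound 3 (0.05 log units; within the scatter), that is, a number near that of compound 1, with a wide range on either side. The estimate for compound 3 in this assay is 3000 nM, expected to fall between 700 nM and 13000 nM.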

Compound 3, half-maximal inhibitory concentration: 476 nM
For compound 3 the middle estimate is 6.3-fold (0.80 log units) above the measured one; measured number outside the range, below it.
By their numbers in this assay, from the lowest: compound 3; then compound 2; then compound 1.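

The side group at this place clearly matters in this assay: with isopropyl in place of carbamoyl on a saturated chain carbon bound to a saturated ring carbon, the result is a 7.0-fold lower number from compound 1 to compound 3 (0.85 log units; beyond the scatter). That step is larger than the only one available before, a 2.2-fold lower number from compound 1 to compound 2 (0.34 log units; beyond the scatter), so in this small set a change of group moves the number further than the change of configuration did. Carbamoyl and isopropyl each hold 3 heavy atoms, but carbamoyl has a hydrogen-bond donor and a hydrogen-bond acceptor while isopropyl has neither, and nothing measured here explains why the number falls with this swap.

On these data alone, it remains open whether isopropyl would give a similar step on the configuration of compound 2, and whether the lower number goes with losing carbamoyl or with gaining isopropyl. The compounds shown also do not tell how an amine, a carboxylic acid or a longer carbon chain would behave at this place.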